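The source may hold more compounds than are shown below. What is called first, only, known or untested is meant among the compounds shown, and "the series" means these compounds.

Two compounds share one core and differ only in the aryl group on an amide-type nitrogen. Compound 1 `S=C(N/N=C/c1ccc2ccccc2n1)Nc1cccc(Br)c1` carries a 3-bromophenyl there, and compound 2 `S=C(N/N=C/c1ccc2ccccc2n1)Nc1ccc(Cl)cc1` a 4-chlorophenyl. In a functional assay on SGC-7901 cells (Homo sapiens) for antiproliferative activity, read by sulforhodamine B assay, with a stated time of 72 h (on this read-out lower numbers stand for stronger inhibition and higher numbers for weaker inhibition), compound 1 gives 78600 nM, and in this assay compound 2 gives 87600 nM. Within the data shown here, the step of a 1.1-fold higher number from compound 1 to compound 2 (0.05 log units; within the scatter) is within the scatter, so compound 2 stands at the upper of the two numbers only nominally, with compound 1 as its sole neighbour at a gap too small to read as a difference.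

Compound 3 `Fc1cccc(NC(=S)N/N=C/c2ccc3ccccc3n2)c1` has not yet been measured. It differs from compound 2 by 3-fluorophenyl in place of 4-chlorophenyl on an amide-type nitrogen. Among the measured compounds shown here, the one step that bears on this change is a 1.1-fold higher number from compound 1 to compound 2 (0.05 log units; within the scatter), itself a swap of one halogenated phenyl for another on the same nitrogen, which moved the number by no more than the scatter. A second such swap is therefore expected to bring no step beyond the scatter in this assay, in either direction, and a 1.0-fold lower number from compound 2 to compound 3 (0.01 log units; within the scatter) is expected to be small. On that basis compound 3 is estimated at 85000 nM, with a range from 35000 nM to 200000 nM.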

Compound 3, half-maximal inhibitory concentration: 79900 nM
Compound 3: middle estimate off by 1.1-fold (0.03 log units), on the high side; the measured number falls inside the stated range.
By their numbers in this assay, from the lowest: compounds 1, 3 and 2 (each within the scatter of the next).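

With 3-fluorophenyl on the amide-type nitrogen, this assay gives a 1.1-fold lower number from compound 2 to compound 3 (0.04 log units; within the scatter) for a change in which both the halogen and its ring position differ, so this second such swap also stays within the scatter. The new pair adds a cleaner comparison: the step of a 1.0-fold higher number from compound 1 to compound 3 (0.01 log units; within the scatter) comes with fluoro in place of bromo on an aromatic carbon while the 3-substituted pattern is kept, whereas the earlier pair changed the halogen and its ring position together. Across these three compounds, then, neither exchange of halogen nor the move from 3-fluorophenyl to 4-chlorophenyl gives a difference that can be read, and nothing given here offers an explanation for this.

On these data alone, all three groups are halogenated phenyl rings, so it remains open whether a methoxy group, an amine or a carboxylic acid on that ring would move the number beyond the scatter. Also open, as far as these compounds go, is whether an unsubstituted phenyl or a saturated cyclohexyl group on this nitrogen would leave the number where it stands.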